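Chloro to Cyano on Two Benzamide Cores

A few compounds are considered here, and "the series" means these few. Any claim that something is new, unique, unknown or untested is made for them only; others in the source may bear on it.

Compound 1 `O=C(Nc1ccc(NS(=O)(=O)C(F)(F)F)c(Cl)c1)c1ccc(Cl)cc1` was assessed in an ADME assay on RAW264.7 cells (Mus musculus) for cytotoxicity, read by MTT assay, with a stated time of 48 h (a lower number here means a stronger inhibitor, a higher number a weaker inhibitor), where compound 1 gives 47200 nM. Compound 2 `N#Cc1ccc(C(=O)Nc2ccc(NS(=O)(=O)C(F)(F)F)c(Cl)c2)cc1` differs from compound 1 by cyano in place of chloro on an aromatic carbon. For compound 2 this assay returns only a limit, > 250000 nM, and not a number. The step of an at least 5.2-fold higher number from compound 1 to compound 2 (0.72 log units; beyond the scatter) therefore rests on (the limit of > 250000 nM in this assay, at which 1 of the 3 values shown sits), so its true size is open at the top.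

Compound 3 `CS(=O)(=O)Nc1ccc(NC(=O)c2ccc(Cl)cc2)cc1F` carries a different core; the difference between the core of compound 3 and the core of compound 1 is not broken down here. In this assay compound 3 gives 22300 nM, the lowest number among the two numbers recorded and beyond the scatter from compound 1.

Compound 4 `CS(=O)(=O)Nc1ccc(NC(=O)c2ccc(C#N)cc2)cc1F` has not yet been measured. It differs from compound 3 by cyano in place of chloro on an aromatic carbon, the same change that separates compound 1 from compound 2, at a place described in the same words. That measured step from compound 1 to compound 2 gives the direction, though its size is known only as a limit. On that basis the expected step of a 6.7-fold higher number from compound 3 to compound 4 (0.83 log units; beyond the scatter) is estimated to run in the same direction, with its size uncertain. Compound 4 is accordingly expected to give around 150000 nM in this assay, in a range from 50000 nM to 400000 nM, with a real chance that only a limit is reported.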

Compound 4, half-maximal inhibitory concentration: > 250000 nM
Compound 4 ended at the assay's limit (the forecaster's own chance of this, stated with the estimate: 40%); middle value at least 1.6-fold (0.22 log units) away from the limit.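

In this assay compound 4 gives > 250000 nM, which is a limit of the assay and not a number. Cyano in place of chloro on an aromatic carbon gives an at least 11-fold higher number from compound 3 to compound 4 (1.04 log units; beyond the scatter) on the core of compound 3, so the direction seen on the core of compound 1 carries over to a second core, and the two steps can be set side by side: the same change on two cores in this assay, an at least 5.2-fold higher number (0.72 log units; beyond the scatter) from compound 1 to compound 2 and an at least 11-fold higher number (1.04 log units; beyond the scatter) from compound 3 to compound 4; the limit leaves it open whether they differ. This does not show that the change has the same size on both cores, nor what its true size is on either, because both cyano compounds rest on a limit and not on a number: the limit of > 250000 nM in this assay, at which 2 of the 4 values shown sit.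

The four compounds shown cover only chloro and cyano at this place on two cores, so they leave open whether other replacements for chloro, such as an amine, a methoxy group or a carboxylic acid, would move the number in the same direction. They also leave open whether the rise seen on these two cores would hold on any further core, and how far beyond the limit either cyano compound really lies.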